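Glucagon receptor urea series: amide tail replacement

A few compounds are considered here, and "the series" means these few. Any claim that something is new, unique, unknown or untested is made for them only; others in the source may bear on it.

Measured so far in an in vitro assay on BHK cells for inhibition of Glucagon receptor (Homo sapiens); a lower number here means a stronger inhibitor, a higher number a weaker inhibitor:
compound 1 `CC(C)(C)[C@H]1CC[C@H](N(Cc2ccc(C(=O)NCCC(=O)O)cc2)C(=O)Nc2ccc(OC(F)(F)F)cc2C#N)CC1`: 56 nM
compound 2 `CC(C)(C)C1CCC(N(Cc2ccc(C(=O)N3CCCC(C(=O)O)C3)cc2)C(=O)Nc2ccc(OC(F)(F)F)cc2)CC1`: 1000 nM

Compound 2 gives the highest number of the two; compound 1 sits well below it, a gap beyond the scatter. Compound 3 `CC(C)(C)C1CCC(N(Cc2ccc(C(=O)NCC(=O)NO)cc2)C(=O)Nc2ccc(OC(F)(F)F)cc2)CC1` is not yet measured. It differs from compound 2 by ((hydroxycarbamoyl)methyl)amino in place of 3-carboxypiperidin-1-yl on a carbonyl carbon. Within the data shown here, no measured pair shows this change, so the step is a guess. Given that compound 2 gives 1000 nM and compound 1 gives 56 nM, a step toward lower numbers is expected, a 3.3-fold lower number from compound 2 to compound 3 (0.52 log units; beyond the scatter), with compound 3 estimated at 300 nM, between 60 nM and 1500 nM.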

Compound 3, half-maximal inhibitory concentration: 2960 nM
Compound 3: the middle estimate sits 9.9-fold (0.99 log units) below what was measured; the measured number lies above the stated range.
By their numbers in this assay, from the lowest: compound 1; then compound 2; then compound 3.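

In this assay, among these compounds, the change from 3-carboxypiperidin-1-yl to ((hydroxycarbamoyl)methyl)amino on a carbonyl carbon gives a 3.0-fold higher number from compound 2 to compound 3 (0.47 log units; beyond the scatter) and is the first single-place step. The tail at this position therefore affects the read-out, and this open-chain replacement does not improve on the ring. No available evidence accounts for the step.

From the compounds shown here alone, the ring and the carboxylic acid leave together in this step, so their separate contributions remain open. A carboxymethylamino group on the same carbonyl carbon would separate the two.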